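Nitro for Trifluoromethyl at the Cytotoxicity Ceiling

The source may report more compounds than this note shows. Statements on the series, on what has been measured and on what is new or still open speak of the compounds shown alone.

Three compounds share one core and differ only in the group carried on the outer aromatic ring. Compound 1 `CCOC(=O)CCCCCOc1cccc(CN(C(=O)c2ccc(-c3ccc4ccccc4c3)cc2)C(C)C)c1` bears naphthalen-2-yl there. In an ADME assay on HEK293 cells (Homo sapiens) for cytotoxicity, read by CellTiter-Glo and resazurin assay, with a stated time of 72 h (a higher number here means that more compound is needed for the effect, a lower number that less compound is needed), compound 1 reaches only the limit of > 26000 nM. Compound 2 `CCOC(=O)CCCCCOc1cccc(CN(C(=O)c2ccc(-c3cccc(OCC)c3)cc2)C(C)C)c1` carries 3-ethoxyphenyl instead, and in this assay compound 2 also stops at a limit, > 22300 nM. Compound 3 `CCOC(=O)CCCCCOc1cccc(CN(C(=O)c2ccc(-c3cccc(C(F)(F)F)c3)cc2)C(C)C)c1` carries 3-(trifluoromethyl)phenyl; in this assay compound 3 gives a limit as well, > 26000 nM. With every value a limit, the steps a step that the two limits leave unreadable from compound 1 to compound 2, a step that the two limits leave unreadable from compound 1 to compound 3 and a step that the two limits leave unreadable from compound 2 to compound 3 cannot be sized: all three compounds sit at the limit of > 22300 nM in this assay, at which 1 of the 3 values shown sits, or (the limit of > 26000 nM in this assay, at which 2 of the 3 values shown sit), and compound 3 stands nowhere above or below its neighbours.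

Compound 4 `CCOC(=O)CCCCCOc1cccc(CN(C(=O)c2ccc(-c3cccc([N+](=O)[O-])c3)cc2)C(C)C)c1` changes compound 3 at the same spot: nitro in place of trifluoromethyl on an aromatic carbon. Among the measured compounds shown here, none of the measured steps gives a readable size, so no direction in this assay can be argued from them; what they do show is that three different groups at this place all left the cells untouched up to the limit. Compound 4 is therefore expected to behave alike, with an estimated step that the limit leaves unreadable from compound 3 to compound 4. The estimate for compound 4 in this assay is 30000 nM, within a range of 12000 nM to 80000 nM, most likely reported as a limit again.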

Compound 4, half-maximal effective concentration: > 26000 nM
Compound 4 gave a limit, no number; the forecaster's own chance of this, stated with the estimate: 80%; the middle value is on the limit's open side.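

In this assay compound 4 gives > 26000 nM, which is a limit and not a number. Among the compounds shown here, compound 1, compound 2 and compound 3 also stand at limits, so no step to compound 4 can be read. The compounds shown leave open where the half-maximal effective concentration of any of the four actually lies, and whether their outer groups differ at all in this measure.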